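Saturating the exocyclic double bond of compound 2

The compounds below may be only part of what the source reports. "The series", "measured", "known", "first", "only" and "open" are said of these compounds alone.

Compound 1 `Cc1c(C)c2c(c(C)c1O)CCC(C)(COc1ccc(/C=C3\SC(=O)NC3=O)cc1)O2`: in an in vivo ADME assay on the whole organism for pharmacokinetics, with Rattus norvegicus as the target, at a dose of 100 mg/kg by the oral route (on this read-out lower numbers stand for lower exposure and higher numbers for higher exposure at the dose given), compound 1 gives 1550 nM.
Compound 2 `Cc1c(C)c2c(c(C)c1OCc1ccccc1)CCC(C)(COc1ccc(/C=C3\SC(=O)NC3=O)cc1)O2`: in this assay compound 2 gives 2060 nM.

Of the two numbers, compound 2 holds the higher one, yet its nearest neighbour is compound 1, and the change from compound 1 to compound 2 a 1.3-fold higher number from compound 1 to compound 2 (0.12 log units; within the scatter), so the two stand together. Compound 3 `Cc1c(C)c2c(c(C)c1OCc1ccccc1)CCC(C)(COc1ccc(CC3SC(=O)NC3=O)cc1)O2` differs from compound 2 in one place: a group of 8 heavy atoms (4 carbon, 1 nitrogen, 2 oxygen, 1 sulfur; one five-membered non-aromatic ring with 2 hetero atoms) in place of a group of 8 heavy atoms (4 carbon, 1 nitrogen, 2 oxygen, 1 sulfur; one five-membered non-aromatic ring with 2 hetero atoms), on an aromatic carbon. The double bond joining the ring to the rest of the molecule is gone, and the group enters as (2,4-dioxo-1,3-thiazolidin-5-yl)methyl on an aromatic carbon, para to a large group. Within the data shown here, no measured step touches this part of the molecule; the only step seen, from compound 1 to compound 2, sits elsewhere and stayed within the scatter. The expected step from compound 2 to compound 3 is therefore a 1.0-fold lower number from compound 2 to compound 3 (0.01 log units; within the scatter), with no movement beyond the scatter. Compound 3 is estimated at 2000 nM, within a range of 700 nM to 6000 nM.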

Compound 3, maximal plasma concentration: 3440 nM
For compound 3 the middle estimate is 1.7-fold (0.24 log units) below the measured one; the range from low to high includes it.
By their numbers in this assay, from the lowest: compounds 1, 2 and 3 (each within the scatter of the next, the first and the last beyond it).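

In this assay, among these compounds, this is the first look at the group on the aromatic carbon, para to a large group, and removing the double bond that joined the ring to the rest of the molecule gives a 1.7-fold higher number from compound 2 to compound 3 (0.22 log units; within the scatter) in one step. Exposure at this dose therefore shows no change beyond the scatter when the group enters as (2,4-dioxo-1,3-thiazolidin-5-yl)methyl, so this position, like the oxygen changed earlier, tolerates the edit on this read-out. No measurement shown here speaks to what lies behind this step.

On these data alone, it remains open whether the same edit behaves alike when the oxygen carries hydrogen rather than benzyl. Also open, as far as these compounds go, is how exposure responds when a carboxylic acid replaces the five-membered ring, or a longer chain links that ring to the aromatic carbon.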